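Methoxy for Methyl on the Amide Aryl Ring

The source may hold more compounds than are shown below. What is called first, only, known or untested is meant among the compounds shown, and "the series" means these compounds.

Compound 1 `CC(C)=CC(=O)Nc1c(C(O)(C(F)(F)F)C(F)(F)F)ccc2ccccc12` — 46 nM
Compound 2 `O=C(Nc1c(C(O)(C(F)(F)F)C(F)(F)F)ccc2ccccc12)c1ccccc1` — 44 nM
Compound 3 `Cc1cccc(C(=O)Nc2c(C(O)(C(F)(F)F)C(F)(F)F)ccc3ccccc23)c1` — 23 nM

In an assay on LtK cells with ATP-sensitive inward rectifier potassium channel 11 (Homo sapiens) as the target (on this read-out higher numbers stand for an effect only at larger amounts of compound and lower numbers for an effect already at smaller amounts), compound 3 gives 23 nM, the smallest of the three numbers, though its steps to both others lie within the scatter: a 1.9-fold lower number from compound 2 to compound 3 (0.28 log units; within the scatter) and a 2.0-fold lower number from compound 1 to compound 3 (0.30 log units; within the scatter). Compound 4 `COc1cccc(C(=O)Nc2c(C(O)(C(F)(F)F)C(F)(F)F)ccc3ccccc23)c1` alters it by methoxy in place of methyl on an aromatic carbon. Among the compounds with values here, no measured step swaps one group for another on this ring; the nearest comparisons are a 1.9-fold lower number from compound 2 to compound 3 (0.28 log units; within the scatter), which adds the methyl, and a 1.0-fold lower number from compound 1 to compound 2 (0.02 log units; within the scatter), both within the scatter. Changes at this end of the amide have so far moved the number little, so compound 4 is expected to land near compound 3, with a 1.3-fold higher number from compound 3 to compound 4 (0.12 log units; within the scatter) expected to stay within the scatter. The estimate for compound 4 is 30 nM, ranging from 12 nM to 75 nM.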

Compound 4, half-maximal effective concentration: 185 nM
Compound 4: middle estimate off by 6.2-fold (0.79 log units), on the low side, outside the stated range (above it).
By their numbers in this assay, from the lowest: compounds 3, 2 and 1 (each within the scatter of the next); then compound 4.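

Unlike the methyl, methoxy on this aromatic carbon moves the number beyond the scatter in this assay (an 8.0-fold higher number from compound 3 to compound 4 (0.91 log units; beyond the scatter)). The change also separates compound 4 from the unsubstituted phenyl amide (a 4.2-fold higher number from compound 2 to compound 4 (0.62 log units; beyond the scatter)) and from the 2-methylprop-1-en-1-yl amide (a 4.0-fold higher number from compound 1 to compound 4 (0.60 log units; beyond the scatter)), so this position is sensitive to which group it carries. Nothing available explains the difference. Still open, from the compounds shown here alone, is how an ethyl group, a chlorine atom or a hydroxyl group would behave on the same carbon, and whether methoxy would cost as much elsewhere on this ring.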